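A Side-Chain Swap on a Shared Core

The source may hold more compounds than are shown below. What is called first, only, known or untested is meant among the compounds shown, and "the series" means these compounds.

Compound 1, `Nc1nn2c(O)cc(-c3ccccc3)nc2c1[N+](=O)[O-]`, carries a phenyl on an aromatic carbon of the shared core. In a functional assay on L929 cells (Mus musculus) for inhibition (a lower number here means a stronger inhibitor of growth, a higher number a weaker inhibitor of growth), compound 1 gives only a limit, > 50 ug/mL, not a number. Compound 2, `NNCc1cc(O)n2nc(N)c([N+](=O)[O-])c2n1`, has an (aminoamino)methyl in place of that phenyl, and in this assay compound 2 gives 35.2 ug/mL. Among the compounds with values here, the step of an at least 1.4-fold lower number from compound 1 to compound 2 (0.15 log units; that floor lies within the scatter) is the only measured step, and its floor lies within the scatter. Compound 2 thus holds the only true number shown. The remaining value, that of compound 1, is a limit: the limit of > 50 ug/mL in this assay, at which 1 of the 2 values shown sits.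

Compound 3, `Nc1nn2c(O)cc(CNCCO)nc2c1[N+](=O)[O-]`, differs from compound 2 in a single place: 2-hydroxyethyl in place of amino on an amine nitrogen. No measured step touches this amine nitrogen; the one step shown exchanged the group on the aromatic carbon, so it does not bear on this change, and no direction can be drawn from it. The expectation is therefore no step beyond the scatter, with a 1.0-fold lower number from compound 2 to compound 3 (0.00 log units; within the scatter) as the estimated change. Compound 3 is expected to give 35 ug/mL, within a range from 15 ug/mL to 80 ug/mL.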

Compound 3, concentration for 50% growth inhibition: > 50 ug/mL
Compound 3: no number, only a limit (the forecaster's own chance of this, stated with the estimate: 30%); middle value at least 1.4-fold (0.15 log units) from the limit.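

On the amine nitrogen, 2-hydroxyethyl in place of amino gives an at least 1.4-fold higher number from compound 2 to compound 3 (0.15 log units; that floor lies within the scatter), so this first change shown at this place offers no sign of a stronger inhibitor of growth, although the size of the step remains unknown and its floor cannot be told apart from ordinary scatter. Within the data shown here, compound 2 therefore still holds the only true number, while the step between compound 1 and compound 3 cannot be read, as each of these two compounds has only a limit. Compound 3 adds a second compound to that limit, which makes it the most common result in the set so far: the limit of > 50 ug/mL in this assay, at which 2 of the 3 values shown sit.

Going by these compounds, what remains open is how far compound 3 actually lies from compound 2, and whether any other group on this amine nitrogen would move the number in either direction. A small methyl, a longer chain such as 3-hydroxypropyl, or a chain ending in a carboxylic acid could each test whether the amino of compound 2 can be replaced on this nitrogen without pushing the result to the limit.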